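From Dichlorophenyl to Difluorophenyl: an Expected Small Shift

The compounds below may be only part of what the source reports. "The series", "measured", "known", "first", "only" and "open" are said of these compounds alone.

Among the compounds with values here, compound 1 `COc1cc(-c2cc(/C=C/C(=O)c3ccc(Cl)c(Cl)c3)[nH]n2)cc(OC)c1OC` gives the highest of the two numbers so far in a functional assay on Hs-578T cells (Homo sapiens) for inhibition, read by sulforhodamine B assay, with a stated time of 48 h (a higher number here means a weaker inhibitor of growth, a lower number a stronger inhibitor of growth), with 16600 nM. Compound 2 `COc1ccc(-c2cc(/C=C/C(=O)c3ccc(N)cc3)[nH]n2)cc1OC` gives 6570 nM in this assay, a gap that lies beyond the usual scatter. Compound 3 `COc1cc(-c2cc(/C=C/C(=O)c3ccc(F)c(F)c3)[nH]n2)cc(OC)c1OC` has not yet been measured; it differs from compound 1 by 3,4-difluorophenyl in place of 3,4-dichlorophenyl on a carbonyl carbon. Within the data shown here, no step between two measured compounds matches this change, so the author expects only a small shift in this assay, barely beyond the scatter if at all, leaning toward a slightly higher number. The estimated step of a 1.2-fold higher number from compound 1 to compound 3 (0.08 log units; within the scatter) is therefore modest. Compound 3 is estimated at 20000 nM, within 8000 nM to 50000 nM.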

Compound 3, concentration for 50% growth inhibition: 3580 nM
Compound 3: middle estimate off by 5.6-fold (0.75 log units), on the high side; measured number below the stated range.
By their numbers in this assay, from the lowest: compounds 3 and 2 (each within the scatter of the next); then compound 1.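

In this assay, exchanging the 3,4-dichlorophenyl group for a 3,4-difluorophenyl group gives a 4.6-fold lower number from compound 1 to compound 3 (0.67 log units; beyond the scatter). This shows that growth inhibition at this position is sensitive to which halogen the phenyl ring carries, even with the rest of compound 1 unchanged. Nothing measured here accounts for the shift. This single pair cannot show whether the response extends to other groups at this position. A phenyl ring bearing a nitrile or trifluoromethyl on the same carbonyl carbon remains an open case, as does a phenyl ring with no substituent.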